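From fluoro to iodo: what to expect for compound 3

A few compounds are considered here, and "the series" means these few. Any claim that something is new, unique, unknown or untested is made for them only; others in the source may bear on it.

In a functional assay on L1210 cells (Mus musculus) for inhibition (a lower number here means that less compound is needed, a higher number that more compound is needed for the effect), compound 1 `N[C@H]1C[C@H](n2ccc(=O)[nH]c2=O)O[C@@H]1CO` gives 18 uM and compound 2 `N[C@@H]1C[C@H](n2cc(F)c(=O)[nH]c2=O)O[C@@H]1CO` gives 15 uM. These two values lie within the usual scatter of each other, so compound 2 stands level with compound 1. Compound 3 `N[C@@H]1C[C@H](n2cc(I)c(=O)[nH]c2=O)O[C@@H]1CO` differs from compound 2 by iodo in place of fluoro on an aromatic carbon. Among the compounds with values here, no measured pair shows what this exchange does in this assay, so no change beyond the scatter is expected, and the estimated step is small: a 1.3-fold higher number from compound 2 to compound 3 (0.12 log units; within the scatter). For compound 3, the estimated value is 20 uM, within a range from 6 uM to 70 uM.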

Compound 3, concentration for half-maximal effect: 400 uM
Beside the measured number, compound 3's estimate is 20-fold (1.30 log units) below it, and the stated range ends below it.
By their numbers in this assay, from the lowest: compounds 2 and 1 (each within the scatter of the next); then compound 3.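

In this assay this position on the aromatic ring proves far from indifferent to its substituent: iodo replacing fluoro gives a 27-fold higher number from compound 2 to compound 3 (1.43 log units; beyond the scatter) and so a clear loss of activity. Each group is a single heavy atom with no hydrogen-bond donors or acceptors, so exchanging one atom here is enough for a large step. No measurement available here accounts for that step.

On these data alone, what chloro, bromo or a methyl group would give on this carbon remains open. The compounds shown therefore cannot tell whether the number climbs steadily across such groups or jumps only with iodo.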